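Methylsulfanyl for cyclohexylmethoxy: expected effect on antiproliferative potency

A few compounds are considered here, and "the series" means these few. Any claim that something is new, unique, unknown or untested is made for them only; others in the source may bear on it.

In a functional assay on MCF7 cells (Homo sapiens) for antiproliferative activity, read by sulforhodamine B assay, with a stated time of 3 days (a lower number here means a stronger inhibitor, a higher number a weaker inhibitor), compound 1 (`c1ccc(Oc2ncnc3[nH]cnc23)cc1`) gives 28400 nM and compound 2 (`c1ccc2c(c1)COC(n1cnc3c(OCC4CCCCC4)ncnc31)CO2`) gives 11600 nM under the same conditions. Compound 2 holds the lower of the two numbers, and its gap to compound 1 lies beyond the usual scatter. Two compounds do not establish a trend.

The next compound is compound 3 (`CSc1ncnc2c1ncn2C1COc2ccccc2CO1`). Relative to compound 2 it carries methylsulfanyl in place of cyclohexylmethoxy on an aromatic carbon. Among the compounds with values here, no measured pair isolates this change, so the expectation rests on little.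

Within the data shown here, the only guide is the range of the two readings, and compound 1 at 28400 nM is the higher reference point. A step beyond the scatter is not expected in this assay for this change, although a slight lean toward a higher number, meaning a weaker inhibitor, seems likely. The estimated step (a 1.4-fold higher number from compound 2 to compound 3 (0.14 log units; within the scatter)) is therefore small and uncertain. For compound 3 the estimated value is 16000 nM with an expected range from 5000 nM to 45000 nM in this test.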

Compound 3, half-maximal inhibitory concentration: 24000 nM
The estimate for compound 3 lay 1.5-fold (0.18 log units) below the measured number; the measured number falls inside the stated range.
By their numbers in this assay, from the lowest: compound 2; then compounds 3 and 1 (each within the scatter of the next).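

In this assay, within the data shown here, the replacement of cyclohexylmethoxy by methylsulfanyl on this aromatic carbon gives the first step between compounds that differ in one place: a 2.1-fold higher number from compound 2 to compound 3 (0.32 log units; beyond the scatter) and it shows that the group at this position affects the read-out, with the smaller methylsulfanyl group giving the weaker inhibitor of this pair. The step is modest even though the change removes the six-membered non-aromatic ring of carbon only and reduces the group from 8 heavy atoms to 2, so in this pair, losing that ring and those atoms costs little potency. Among these compounds, the single pair cannot separate the effect of the ring from that of exchanging the linking oxygen for sulfur, and no measurement available here gives a cause for the step.

Still open, going by these compounds, is whether the linking atom or the group beyond it matters more, which a pair such as methoxy against methylsulfanyl, or cyclohexylmethylsulfanyl against cyclohexylmethoxy, would address. On these data alone, it is also open how an amine or a longer alkyl chain on the same aromatic carbon would read in this assay and whether this step carries over to other members.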